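Swapping an Aminophenyl for a Trifluoromethylphenyl Group

The source may report more compounds than this note shows. Statements on the series, on what has been measured and on what is new or still open speak of the compounds shown alone.

Of the compounds shown here, three sharing one core have been measured in an assay for binding affinity to dual specificity mitogen-activated protein kinase kinase 4 (Homo sapiens), read by KINOMEscan, tested at 100 nM; on this read-out higher numbers stand for a weaker effect at the one concentration tested and lower numbers for a stronger effect. Compound 1 `CCCS(=O)(=O)Nc1ccc(F)c(C(=O)c2n[nH]c3ncc(-c4ccccc4C)cc23)c1F` gives 7%. Compound 2 `CCCS(=O)(=O)Nc1ccc(F)c(C(=O)c2n[nH]c3ncc(-c4ccccc4N)cc23)c1F` gives 23%. Compound 3 `CCCS(=O)(=O)Nc1ccc(F)c(C(=O)c2n[nH]c3ncc(-c4ccc(N)cc4)cc23)c1F` gives 0.1%. On these numbers compound 2 stands highest, meaning the weakest effect at the single concentration: a number 16 percentage points higher from compound 1 to compound 2 (beyond the scatter) and a number 22.9 percentage points lower from compound 2 to compound 3 (beyond the scatter), both beyond the scatter, while a number 6.9 percentage points lower from compound 1 to compound 3 (within the scatter) stays within it.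

Compound 4 `CCCS(=O)(=O)Nc1ccc(F)c(C(=O)c2n[nH]c3ncc(-c4ccc(C(F)(F)F)cc4)cc23)c1F` has not yet been measured. It differs from compound 2 in one place: 4-(trifluoromethyl)phenyl in place of 2-aminophenyl on an aromatic carbon. The step of a number 22.9 percentage points lower from compound 2 to compound 3 (beyond the scatter) bears most on this change, as it too removed the 2-aminophenyl; the step of a number 16 percentage points higher from compound 1 to compound 2 (beyond the scatter) shows the 2-aminophenyl sitting above the 2-methylphenyl. Among the measured compounds shown here, a downward step is therefore expected, though the trifluoromethyl group has no measured counterpart, so the range is wide. The expected step is a number 17 percentage points lower from compound 2 to compound 4 (beyond the scatter). For compound 4 the estimate is 6%, between 0.5% and 30%.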

Compound 4, a percentage reported as activity, at one concentration (the size of the read-out at that concentration, not a potency): 29%
For compound 4 the middle estimate is 23 percentage points below the measured one; the range from low to high includes it.
By their numbers in this assay, from the lowest: compounds 3 and 1 (each within the scatter of the next); then compounds 2 and 4 (each within the scatter of the next).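

In this assay, the step of a number 28.9 percentage points higher from compound 3 to compound 4 (beyond the scatter) shows that a group placed on the 4-position of this phenyl ring does not by itself give a strong effect, since trifluoromethyl and amino part clearly there. The 4-(trifluoromethyl)phenyl group also separates from the 2-methylphenyl group, with a number 22 percentage points higher from compound 1 to compound 4 (beyond the scatter) as the step, yet it cannot be told apart from the 2-aminophenyl group, with a number 6 percentage points higher from compound 2 to compound 4 (within the scatter) as the step. No measured evidence is at hand to explain these differences.

Still open, on these data alone, is whether the result of compound 3 is particular to the amino group. A hydroxyl, a methoxy or an aminomethyl group in its place on the phenyl ring would help to settle that.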